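The source may hold more compounds than are shown below. What is called first, only, known or untested is meant among the compounds shown, and "the series" means these compounds.

Measured compounds:
- compound 1, `Cc1ccc(NC(=O)c2ccc(/N=N\c3c[nH]c4ccccc34)cc2)cc1`, 300 nM in a functional assay on P388 cells (Mus musculus) for inhibition, read by MTT assay, with a stated time of 72 h; a lower number here means a stronger inhibitor, a higher number a weaker inhibitor
- compound 2, `O=C(Nc1ccccc1Cl)c1ccc(/N=N\c2c[nH]c3ccccc23)cc1`, "not active" (no number reported) in this assay, without a number

Going by the values given here, compound 1 therefore holds the only number in this assay; the second entry gives no figure to set beside it, so there is no measured step to draw on.

The unmeasured compound 3 is `Cc1ccc(C)c(NC(=O)c2ccc(/N=N\c3c[nH]c4ccccc34)cc2)c1`. It differs from compound 1 at a single place: 2,5-dimethylphenyl in place of 4-methylphenyl on an amide-type nitrogen. Both groups are plain carbon rings with no hydrogen-bond donors or acceptors, and the change adds one carbon.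

Among the compounds with values here, with no step between measured compounds and only one number in hand, the expectation rests on the shape of the change alone. A modest loss of potency seems the more likely outcome, though a result within the usual scatter cannot be ruled out. The expected step from compound 1 to compound 3 is a 3.3-fold higher number from compound 1 to compound 3 (0.52 log units; beyond the scatter). Compound 3 is thus estimated at 1000 nM in this assay, with a range from 300 nM to 5000 nM.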

Compound 3, half-maximal inhibitory concentration: "not active" (no number reported)
Compound 3 has no reported number here; the estimate stays without a comparison.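

Compound 3 is reported as not active in this assay without a number, so compound 1 at 300 nM has no figure to be set against and no step can be read. The compounds shown leave open how far 2,5-dimethylphenyl in place of 4-methylphenyl moves the number. No further data here bear on this result.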